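The source may hold more compounds than are shown below. What is called first, only, known or untested is meant among the compounds shown, and "the series" means these compounds.

Among the compounds with values here, in an ADME assay (liver) for metabolic stability, with Liver microsome (Rattus norvegicus) as the target, using microsomes and NADPH, with a stated time of 30 min, tested at 1 uM (a higher number here means faster removal of the compound, a lower number slower removal), compound 2, whose structure is `Nc1ccc(S(=O)(=O)N2CCN(c3ncc(C(O)(C(F)(F)F)C(F)(F)F)cc3C#CCCO)CC2)cn1`, gives 68 mL.min-1.g-1, the highest of the two numbers measured so far. Within the data shown here, the nearest is compound 1, with structure `Nc1ccc(S(=O)(=O)N2CCN(c3ncc(C(O)(C(F)(F)F)C(F)(F)F)cc3Br)CC2)cn1`, which in this assay gives 32 mL.min-1.g-1; the one measured step runs a 2.1-fold higher number from compound 1 to compound 2 (0.33 log units; beyond the scatter).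

Compound 3, with structure `Cc1nc2cc(-c3cc(C(O)(C(F)(F)F)C(F)(F)F)cnc3N3CCN(S(=O)(=O)c4ccc(N)nc4)CC3)ccc2o1`, has not been measured. It differs from compound 2 in one place: 2-methyl-1,3-benzoxazol-5-yl in place of 4-hydroxybut-1-yn-1-yl on an aromatic carbon.

Among the measured compounds shown here, only one step has been measured, and it concerns a different exchange, bromo for 4-hydroxybut-1-yn-1-yl, so it gives no direct guide to what happens when a 2-methyl-1,3-benzoxazol-5-yl group enters in place of the 4-hydroxybut-1-yn-1-yl group. For the measured compounds named here, that step was modest, and with no measured step touching the entering group, the change from compound 2 to compound 3 is expected to stay within a modest range in either direction, quite possibly within the scatter. For compound 3 the estimated result in this assay is 55 mL.min-1.g-1, with a range from 20 mL.min-1.g-1 to 150 mL.min-1.g-1, which corresponds to an expected step of a 1.2-fold lower number from compound 2 to compound 3 (0.09 log units; within the scatter).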

Compound 3, intrinsic clearance in microsomes: 99 mL.min-1.g-1
Compound 3: middle estimate off by 1.8-fold (0.26 log units), on the low side, and the stated range covers the measured number.
By their numbers in this assay, from the lowest: compound 1; then compounds 2 and 3 (each within the scatter of the next).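

Compared at this place, on an aromatic carbon two atoms from the ring nitrogen, the open 4-hydroxybut-1-yn-1-yl chain and the fused aromatic 2-methyl-1,3-benzoxazol-5-yl group cannot be told apart in this assay: the result is a 1.5-fold higher number from compound 2 to compound 3 (0.16 log units; within the scatter), and the hydrogen-bond donor carried by the chain, absent from the entering group, leaves no readable mark. The clear contrast among these compounds is with bromo, seen in a 3.1-fold higher number from compound 1 to compound 3 (0.49 log units; beyond the scatter), which extends the earlier reading of a 2.1-fold higher number from compound 1 to compound 2 (0.33 log units; beyond the scatter) from one replacement of bromo to two very different ones, with no compound shown going against it. Nothing measured here explains why these replacements behave alike, and no supporting data bear on the result.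

On these data alone, what stays open is whether a small group such as methyl or an amine at this place would give a number close to that of compound 1 or to those of compound 2 and compound 3. As far as these compounds go, it also remains open whether a plain phenyl ring, or a longer chain ending in a carboxylic acid, would fit the same picture.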